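Compound 3 to compound 4 under a shared limit

The source may hold more compounds than are shown below. What is called first, only, known or untested is meant among the compounds shown, and "the series" means these compounds.

Measured compounds in a functional assay on MDA-MB-231 cells (Homo sapiens) for antiproliferative activity, read by CCK-8 assay, with a stated time of 48 h; a higher number here means a weaker inhibitor, a lower number a stronger inhibitor (each value is a limit of the assay, not a number):
- Compound 1 `C=C(C)C(=O)NCCOc1ccc(Oc2c(-c3ccc(F)cc3)sc3cc(O)ccc23)cc1` gives > 50000 nM
- Compound 2 `CNC(=O)/C=C/CNCCOc1ccc(Oc2c(-c3ccc(F)cc3)sc3cc(O)ccc23)cc1` gives > 50000 nM
- Compound 3 `CN(C)C(=O)/C=C/CNCCOc1ccc(Oc2c(-c3ccc(F)cc3)sc3cc(O)ccc23)cc1` gives > 50000 nM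

Compound 3 therefore has no exact position on the scale. It shares with the other two compounds (the limit of > 50000 nM in this assay, at which 3 of the 3 values shown sit), so none of the three can be ranked against the others.

The next structure is compound 4 `O=C(CCCNCCOc1ccc(Oc2c(-c3ccc(F)cc3)sc3cc(O)ccc23)cc1)N1CCC1`. Its change from compound 3 is 2-((azetidin-1-yl)carbonyl)ethyl in place of 2-(dimethylcarbamoyl)ethenyl on a saturated chain carbon bound to an amine nitrogen. In words, 2-((azetidin-1-yl)carbonyl)ethyl stands in place of 2-(dimethylcarbamoyl)ethenyl on a saturated chain carbon bound to an amine nitrogen.

The measured steps offer little guidance. The closest ones are a step that the two limits leave unreadable from compound 2 to compound 3 and a step that the two limits leave unreadable from compound 1 to compound 3, and a step that the two limits leave unreadable from compound 1 to compound 2 is no clearer. None has a size, and none tests this exact replacement. The only firm observation is that all three compounds stop at the same limit, so no step beyond the scatter is expected in this assay, and no direction can be favoured.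

The estimated step is a number no higher from compound 3 to compound 4 (the limit leaves the size open), which is a cautious expectation. Compound 4 is expected near 50000 nM, with an estimated range from 20000 nM to 100000 nM, and the assay may well report only a limit again.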

Compound 4, half-maximal inhibitory concentration: > 50000 nM
Compound 4 gave a limit, no number; the forecaster's own chance of this, stated with the estimate: 80%; the middle value lies on the limit itself.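

Compound 4 also gives only a limit of the assay, not a number, so no step from compound 1, compound 2 or compound 3 to compound 4 can be read, and the four cannot be ranked: the limit of > 50000 nM in this assay, at which 4 of the 4 values shown sit.

The compounds shown leave open what exact value any of them would have in this assay, and whether any of these changes moves it.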